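Working notes: replacing the end group of compound 1

A few compounds are considered here, and "the series" means these few. Any claim that something is new, unique, unknown or untested is made for them only; others in the source may bear on it.

Measured in a physicochemical assay for solubility, with a stated time of 24 h, at pH 6.8; a lower number here means a less soluble compound, a higher number a more soluble compound:
- compound 1 `O=C(NC[C@@H]1[C@H]2CN(C(=O)C3CC3c3cc(Cl)cc(Cl)c3)C[C@@H]12)c1ccc2[nH]c(=O)oc2c1`: < 1 ug/mL, a limit
- compound 2 `O=C(NC[C@@H]1[C@H]2CN(C(=O)OCc3cc(C(F)(F)F)cc(C(F)(F)F)c3)C[C@@H]12)c1ccc2[nH]c(=O)oc2c1`: < 1 ug/mL, a limit

Compound 1 gives no number, only the limit < 1 ug/mL. For the measured compounds named here, its position is the one shared by every compound measured so far: the limit of < 1 ug/mL in this assay, at which 2 of the 2 values shown sit. Compound 3 `Cc1cc(COC(=O)N2C[C@@H]3[C@@H](CNC(=O)c4ccc5[nH]c(=O)oc5c4)[C@@H]3C2)no1` keeps the core of compound 1 and carries (5-methyl-1,2-oxazol-3-yl)methoxy on the carbonyl carbon, with a five-membered aromatic ring with 2 hetero atoms now present: a group of 8 heavy atoms (5 carbon, 1 nitrogen, 2 oxygen; one five-membered aromatic ring with 2 hetero atoms) in place of a group of 11 heavy atoms (9 carbon, 2 chlorine; one three-membered non-aromatic ring of carbon only, one six-membered aromatic ring of carbon only), on a carbonyl carbon. Going by the values given here, no measured pair sizes such a change, so the expectation rests on the structural change alone. An upward step in this assay is expected, clearly beyond the usual scatter, though its size is uncertain. The estimated step is an at least 40-fold higher number from compound 1 to compound 3 (1.60 log units; beyond the scatter). Compound 3 is expected at 40 ug/mL, with an estimated range from 6 ug/mL to 200 ug/mL.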

Compound 3, solubility: 63 ug/mL
For compound 3 the middle estimate is 1.6-fold (0.20 log units) below the measured one, within the range that was stated.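

In this assay replacing the end group on the carbonyl carbon with (5-methyl-1,2-oxazol-3-yl)methoxy gives an at least 63-fold higher number from compound 1 to compound 3 (1.79 log units; beyond the scatter). The value of compound 1 is a limit, < 1 ug/mL, so the full size of this step cannot be read. This position can nevertheless carry the read-out clear of the limit, which the earlier compounds did not show: the limit of < 1 ug/mL in this assay, at which 2 of the 3 values shown sit.

The whole group changes at once, so the compounds shown do not separate the contribution of the five-membered aromatic ring from that of the oxygen link or of the two chlorine atoms that leave. Also open, from the compounds shown here alone, is how an amine, a carboxylic acid or a longer chain on the same carbonyl carbon would read in this assay.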